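Ester variation on the furan-bearing core

This account rests on a few compounds, and the source may have more. Where it says the series, first, only, none or still open, it means among the compounds named here.

Compound 1 `CC1=C(C(=O)OCc2ccccc2)C(c2ccco2)NC(=O)N1` gives 36% in an assay on membranes from CHO cells for displacement of a labelled ligand from adenosine receptor A1 (Homo sapiens), read by scintillation counting, with a stated time of 60 min, tested at 1 uM (a higher number here means more inhibition at the concentration tested (going by the name of the read-out), a lower number less inhibition), the lowest of the two numbers obtained so far. Compound 2 `CC1=C(C(=O)OCc2ccccc2)C(c2ccsc2)NC(=O)N1` gives 57% in this assay; the step of a number 21 percentage points higher from compound 1 to compound 2 (beyond the scatter) concerns the saturated ring carbon and not the ester. Compound 3 `CC1=C(C(=O)OCC2CC2)C(c2ccco2)NC(=O)N1` differs from compound 1 by cyclopropyl in place of phenyl on a saturated chain carbon bound to an oxygen next to a carbonyl group. Among the compounds with values here, no measured step touches the ester, so nothing observed bears directly on this change; a step within the scatter, in either direction, is expected. Compound 3 is therefore estimated at 35%, between 15% and 55%. For compound 3 the expected step is a number 1 percentage points lower from compound 1 to compound 3 (within the scatter).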

Compound 3, a percentage reported as inhibition, at one concentration (the size of the read-out at that concentration, not a potency): 29%
Compound 3: middle estimate off by 6 percentage points, on the high side; low and high end bracket the measured number.
By their numbers in this assay, from the lowest: compounds 3 and 1 (each within the scatter of the next); then compound 2.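

In this assay, the ester position now has a first reading: cyclopropyl in place of phenyl on a saturated chain carbon bound to an oxygen next to a carbonyl group gives a number 7 percentage points lower from compound 1 to compound 3 (within the scatter). With furan-2-yl kept on the shared core, the change from benzyl to cyclopropylmethyl, which exchanges the six-membered aromatic ring for a three-membered non-aromatic ring, stays within the scatter. No measured evidence accounts for this outcome.

Open, going by these compounds, is whether cyclopropylmethyl gives a similar reading alongside the thiophen-3-yl group of compound 2. Also open, on these data alone, is how a longer chain or an amine-bearing chain in place of benzyl would read.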